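A few compounds are considered here, and "the series" means these few. Any claim that something is new, unique, unknown or untested is made for them only; others in the source may bear on it.

Two compounds of the series have numbers in an assay (Rattus norvegicus) for inhibition of Fatty-acid amide hydrolase 1 (Homo sapiens) (a lower number here means a stronger inhibitor, a higher number a weaker inhibitor), so far. Compound 1 `Cc1cccc(-c2cnc(C(=O)CCCCCCc3ccccc3)o2)n1` gives 3.3 nM, and compound 2 `NS(=O)(=O)c1ccc(-c2cnc(C(=O)CCCCCCc3ccccc3)o2)s1` gives 3 nM. The step of a 1.1-fold lower number from compound 1 to compound 2 (0.04 log units; within the scatter) exchanges one aromatic group for another on the shared core and leaves the number essentially where it was. Compound 2 therefore stands at the lowest of the two numbers, with compound 1 within the scatter of it, so no order between the two can be read.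

Compound 3 `O=C(CCCCCCc1ccccc1)c1ncc(Cl)o1` is not yet measured. It differs from compound 2 in one place: chloro in place of 5-sulfamoylthiophen-2-yl on an aromatic carbon. The step from compound 1 to compound 2 only shows that one aromatic group can stand in for another at this position without a shift beyond the scatter; it says nothing about removing the aromatic group altogether in favor of a single chlorine. Among the compounds with values here, no measured step bears directly on that change. With the large group gone, the number for compound 3 is expected to move upward, by roughly a 20-fold higher number from compound 2 to compound 3 (1.30 log units; beyond the scatter), giving an estimate of 60 nM with a range from 15 nM to 250 nM.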

Compound 3, inhibition constant: 5 nM
Compound 3: the middle estimate sits 12-fold (1.08 log units) above what was measured; measured number below the stated range.
By their numbers in this assay, from the lowest: compounds 2, 1 and 3 (each within the scatter of the next).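

In this assay, the aromatic carbon next to the ring oxygen does not depend on an aromatic group: chloro in place of 5-sulfamoylthiophen-2-yl gives a 1.7-fold higher number from compound 2 to compound 3 (0.22 log units; within the scatter), and chloro in place of 6-methylpyridin-2-yl gives a 1.5-fold higher number from compound 1 to compound 3 (0.18 log units; within the scatter). A single chlorine with no ring therefore stands in for the 9 heavy atoms of 5-sulfamoylthiophen-2-yl, including its 1 hydrogen-bond donor and 3 hydrogen-bond acceptors, without a shift beyond the scatter. No available evidence accounts for this result.

The compounds shown leave open what a bare hydrogen, an amine or a carboxylic acid on this carbon would give. They also leave open whether this insensitivity to the group holds with a shorter chain on the carbonyl.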